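A few compounds are considered here, and "the series" means these few. Any claim that something is new, unique, unknown or untested is made for them only; others in the source may bear on it.

Working notes on the series.

Compound 3 `Nc1scc(CN2CCN(c3cccc4ccccc34)CC2)c1C(=O)c1ccc(Cl)cc1` gives 2.9% in a functional assay on CHO cells with adenosine receptor A1 (Homo sapiens) as the target, read by cAMP accumulation and immunoassay, with a stated time of 6 min, tested at 1 uM; a lower number here means a stronger effect, a higher number a weaker effect of the compound at the concentration tested. Among the three numbers so far it is the second highest; compound 2 `Nc1scc(CN2CCN(C3CCCCCC3)CC2)c1C(=O)c1ccc(Cl)cc1` gives 3.7% and sits within the usual scatter of compound 3, so no order between the two can be claimed, while compound 1 `Nc1scc(CN2CCN(c3cccc(C(F)(F)F)c3)CC2)c1C(=O)c1ccc(Cl)cc1` gives -72%, far lower.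

Compound 4 `Nc1scc(CN2CCN(c3c(F)cccc3F)CC2)c1C(=O)c1ccc(Cl)cc1` is the next step. It differs from compound 3 as follows: 2,6-difluorophenyl in place of naphthalen-1-yl on an amine nitrogen in a ring.

Among the measured compounds shown here, of the measured steps, a number 74.9 percentage points higher from compound 1 to compound 3 (beyond the scatter) is the one that touches the group now being exchanged, and it is large. The parallel change a number 75.7 percentage points higher from compound 1 to compound 2 (beyond the scatter) was of the same size, and a number 0.8 percentage points lower from compound 2 to compound 3 (within the scatter) was within the scatter. Both large steps moved away from the single aromatic ring with a trifluoromethyl group toward either a larger aromatic system or a saturated ring. For the measured compounds named here, compound 4 returns to a single aromatic ring, though now with two fluorines rather than a trifluoromethyl; no measured step tells how that particular ring behaves.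

On this basis compound 4 is expected to move back part of the way toward compound 1, giving an estimated step of a number 32.9 percentage points lower from compound 3 to compound 4 (beyond the scatter) in this assay. The estimate for compound 4 is -30%, with a range from -75% to 10%.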

Compound 4, a percentage reported as activity, at one concentration (the size of the read-out at that concentration, not a potency): -65%
Estimate against measurement, compound 4: 35 percentage points above; measured number inside the range.
By their numbers in this assay, from the lowest: compounds 1 and 4 (each within the scatter of the next); then compounds 3 and 2 (each within the scatter of the next).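

In this assay, replacing naphthalen-1-yl with 2,6-difluorophenyl on the amine nitrogen in a ring gives a large step (a number 67.9 percentage points lower from compound 3 to compound 4 (beyond the scatter)), and replacing cycloheptyl with the same group gives another (a number 68.7 percentage points lower from compound 2 to compound 4 (beyond the scatter)), so the low number of compound 1 does not depend on a trifluoromethyl group. The comparison with that compound (a number 7 percentage points higher from compound 1 to compound 4 (within the scatter)) allows no order between 2,6-difluorophenyl and 3-(trifluoromethyl)phenyl, even though the two groups carry different substituents. Across the four compounds, the two substituted phenyl groups give the low numbers and naphthalen-1-yl and cycloheptyl the high numbers, with no compound against this split, and compound 3 shows that an aromatic group alone does not bring a compound to the low end.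

No measurement available here accounts for this split. The compounds shown leave open whether a phenyl group without substituents, or a phenyl group bearing a methoxy group or a carboxylic acid, would fall with compounds 1 and 4 or with compounds 2 and 3.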